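A few compounds are considered here, and "the series" means these few. Any claim that something is new, unique, unknown or untested is made for them only; others in the source may bear on it.

Measured in an ADME assay on microsomes from liver (Homo sapiens) for metabolic stability; on this read-out higher numbers stand for a longer-lived compound and lower numbers for a shorter-lived compound:
- compound 1 `CC#C[C@@H](Cc1nnn[nH]1)c1ccc(OCc2ccc3scc(-c4ccc(OCCCS(C)(=O)=O)cc4C)c3c2)cc1`: 1.28 h
- compound 2 `CC#C[C@@H](Cc1nnn[nH]1)c1ccc(OCc2ccc3scc(C4CCCCC4)c3c2)cc1`: 0.183 h
- compound 3 `CC#C[C@@H](Cc1nnn[nH]1)c1ccc(OCc2ccc3scc(-c4ccc(OCCOC)cc4C)c3c2)cc1`: 0.717 h

Compound 3 stands level with compound 1 within the scatter and clear of compound 2, with a 3.9-fold higher number from compound 2 to compound 3 (0.59 log units; beyond the scatter). The next compound is compound 4 `CC#C[C@@H](Cc1nnn[nH]1)c1ccc(OCc2ccc3scc(-c4ccc(OCCC(C)(C)O)cc4C)c3c2)cc1`, with this difference: 1-hydroxy-1-methylethyl in place of methoxy on a saturated chain carbon, two bonds along the chain from an oxygen on an aromatic ring. In words, 1-hydroxy-1-methylethyl replaces methoxy on a saturated chain carbon, two bonds along the chain from an oxygen on an aromatic ring.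

The same place has one measured change, a 1.8-fold lower number from compound 1 to compound 3 (0.25 log units; within the scatter). This is the closest guide, and it stays inside the scatter. The change from cyclohexyl at the aromatic carbon is the larger step, but it lies elsewhere and says little about the chain end. Among the compounds with values here, no measured compound carries a hydroxy group on this chain, so the basis is thin.

No step beyond the scatter is expected in this assay, and the direction is only weakly upward. The expected step is a 1.3-fold higher number from compound 3 to compound 4 (0.10 log units; within the scatter). Compound 4 is estimated at 0.9 h, with an expected range of 0.45 h to 1.8 h.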

Compound 4, half-life: 0.95 h
The estimate for compound 4 lay 1.1-fold (0.02 log units) below the measured number; the measured number falls inside the stated range.
By their numbers in this assay, from the lowest: compound 2; then compounds 3, 4 and 1 (each within the scatter of the next).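

In this assay, within the data shown here, a hydroxy-bearing chain end appears at this place for the first time, and 3-hydroxy-3-methylbutoxy stays level with 2-methoxyethoxy (a 1.3-fold higher number from compound 3 to compound 4 (0.12 log units; within the scatter)) and with the chain ending in (methylsulfonyl)methyl (a 1.3-fold lower number from compound 1 to compound 4 (0.13 log units; within the scatter)). An ether, a tertiary alcohol and a methyl sulfone at this chain end therefore all fall within the scatter of one another, so a hydrogen-bond donor can enter here without a step beyond the scatter. Nothing available bears on the reason for this.

The three chain ends shown are all uncharged, so an amine or a carboxylic acid at the same place remains an open case. Also open, as far as these compounds go, is whether a longer chain, or a hydroxy group without the two methyl groups, would stay level with these compounds.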